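A few compounds are considered here, and "the series" means these few. Any claim that something is new, unique, unknown or untested is made for them only; others in the source may bear on it.

Measured so far:
- compound 1, `CCc1ccc2nc(C(=O)Nc3c(F)cc(-c4cccc(F)c4)cc3F)c(C)c(O)c2c1`: 17.9%
- compound 2, `Cc1c(C(=O)Nc2ccc(-c3ccccc3)cc2)nc2ccccc2c1O`: 17.3%
- compound 3, `CCOc1ccc2nc(C(=O)Nc3c(F)cc(-c4cccc(F)c4)cc3F)c(C)c(C(=O)O)c2c1`: 35.2%

All three numbers come from a functional assay on A-375 cells (Homo sapiens) for antiproliferative activity, read by MTT assay, with a stated time of 24 h, tested at 3.7 ug/mL; a lower number here means a weaker effect, a higher number a stronger effect of the compound at the concentration tested. Compound 2 and compound 1 give numbers that lie within the usual scatter of each other, so nothing separates them. For the measured compounds named here, compound 3 gives a number beyond the scatter above compound 2; compound 3 differs from compound 2 in several places at once, so its higher number cannot be tied to any single one of them, and no one-place step between measured compounds exists in this set.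

Compound 4, `Cc1c(C(=O)Nc2ccc(-c3ccccc3)cc2)nc2ccccc2c1C(=O)O`, is not yet measured. It differs from compound 2 in one place:

carboxy in place of hydroxy on an aromatic carbon

Going by the values given here, the only measured compound carrying the carboxy group, compound 3, also carries other changes, so the weight of the carboxy alone is unknown. The expectation for the step of a number 7.7 percentage points higher from compound 2 to compound 4 (within the scatter) is therefore a modest rise in this assay, of a size that may or may not clear the scatter. Compound 4 is estimated at 25%, with a range from 12% to 40%.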

Compound 4, a percentage reported as inhibition, at one concentration (the size of the read-out at that concentration, not a potency): 16.3%
For compound 4 the middle estimate is 8.7 percentage points above the measured one; measured number inside the range.
By their numbers in this assay, from the lowest: compounds 4, 2 and 1 (each within the scatter of the next); then compound 3.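

At this position, on an aromatic carbon opposite the ring nitrogen and ortho to a methyl group, carboxy in place of hydroxy reads in this assay as a number 1 percentage points lower from compound 2 to compound 4 (within the scatter). For the compounds shown here, this is the first one-place reading, and it shows that on the core of compound 2, at the single concentration tested, this read-out does not separate the hydroxy group from the carboxy group, so the exchange can be made here without a measurable shift in either direction. Nothing measured in the series bears on why the two groups read alike.

Open, as far as these compounds go, is whether other groups at the same carbon, such as an amine, a methyl ester or a primary carboxamide, would also leave the number within the scatter of compound 2 or would move it clearly. Also open, from the compounds shown here alone, is whether carboxy in place of hydroxy reads the same way on the fluorinated core of compound 1, where the same exchange could be tested as a single change.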